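The compounds below may be only part of what the source reports. "The series", "measured", "known", "first", "only" and "open" are said of these compounds alone.

Working notes on the series. Among the measured compounds shown here, three analogues with a shared core have numbers so far. In a functional assay on HT-29 cells (Homo sapiens) for cytotoxicity, read by MTT assay, with a stated time of 72 h (a lower number here means a stronger inhibitor, a higher number a weaker inhibitor), compound 1 `COc1cc2c(Oc3ccc(NC(=O)N/N=C/c4ccc(C(F)(F)F)cc4)cc3F)ccnc2cc1OCCCN1CCCC1` gives 810 nM. Compound 2 `COc1ccc(/C=N/NC(=O)Nc2ccc(Oc3ccnc4cc(OCCCN5CCCCC5)c(OC)cc34)c(F)c2)cc1` gives 590 nM in this assay. Compound 3 `COc1ccc(/C=N/NC(=O)Nc2ccc(Oc3ccnc4cc(OCCCN5CCCCC5)c(OC)cc34)c(F)c2)c(OC)c1` gives 1600 nM, the highest of the three numbers; its gap to compound 1 lies within the scatter, while the step of a 2.7-fold higher number from compound 2 to compound 3 (0.43 log units; beyond the scatter) lies beyond it. Compound 4 `COc1cc2c(Oc3ccc(NC(=O)N/N=C/c4cc5ccccc5[nH]4)cc3F)ccnc2cc1OCCCN1CCCCC1` differs from compound 3 by 1H-indol-2-yl in place of 2,4-dimethoxyphenyl on a carbon with a double bond to nitrogen. For the measured compounds named here, no measured step covers this exchange; the one measured step in this part of the molecule, a 2.7-fold higher number from compound 2 to compound 3 (0.43 log units; beyond the scatter), followed a single added methoxy, and compound 1 with its trifluoromethyl group sits close to compound 3. A modest step back toward the lower numbers of the set is therefore expected, of size a 2.3-fold lower number from compound 3 to compound 4 (0.36 log units; beyond the scatter). For compound 4 the estimate in this assay is 700 nM, with a range from 250 nM to 2000 nM.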

Compound 4, half-maximal inhibitory concentration: 820 nM
Compound 4: the middle estimate sits 1.2-fold (0.07 log units) below what was measured, and the stated range covers the measured number.
By their numbers in this assay, from the lowest: compounds 2, 1, 4 and 3 (each within the scatter of the next, the first and the last beyond it).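

In this assay the carbon with a double bond to nitrogen carries 1H-indol-2-yl, with its five-membered aromatic ring and hydrogen-bond donor, without a step beyond the scatter from either close analogue (a 2.0-fold lower number from compound 3 to compound 4 (0.29 log units; within the scatter); a 1.4-fold higher number from compound 2 to compound 4 (0.14 log units; within the scatter)). Among the compounds shown here, earlier compounds showed only a single six-membered aromatic ring of carbon only at this place, so this exchange widens what the position is seen to carry. Nothing measured bears on the cause of these steps. Still open, as far as these compounds go, is whether an amine or a carboxylic acid on the ring at this place would move the number beyond the scatter from compound 4.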